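This account rests on a few compounds, and the source may have more. Where it says the series, first, only, none or still open, it means among the compounds named here.

In a functional assay on MCF7 cells (Homo sapiens) for cytotoxicity, read by MTT assay, with a stated time of 72 h (on this read-out lower numbers stand for stronger inhibition of growth and higher numbers for weaker inhibition of growth), measured so far:

compound 1 `CS/C(=N\C(=O)c1csc([N+](=O)[O-])c1)NC(=O)c1csc([N+](=O)[O-])c1`: 44700 nM
compound 2 `O=C(/N=C(/NC(=O)c1cc(-c2ccccc2)nc2ccccc12)[Se]Cc1ccccc1)c1cc(-c2ccccc2)nc2ccccc12`: 8460 nM

Compound 1 stands highest of the two numbers recorded in this assay; the nearest is compound 2, whose number lies beyond the scatter below that of compound 1. Among the measured compounds shown here, no step between the two is counted, since they differ in more than one place, and their values show only that compound 2 sits lower.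

Compound 3 `C[Se]/C(=N\C(=O)c1csc([N+](=O)[O-])c1)NC(=O)c1csc([N+](=O)[O-])c1` is not yet measured. It differs from compound 1 in one place: a group of 2 heavy atoms (1 carbon, 1 selenium; no ring) in place of a group of 2 heavy atoms (1 carbon, 1 sulfur; no ring), on a carbon with a double bond to nitrogen. For the measured compounds named here, no measured pair isolates this exchange, so the size of the step has no precedent among the compounds here. The expectation is a small step toward a lower number, of a size close to the edge of the usual scatter, with the possibility that no difference beyond scatter appears at all. Compound 3 is expected to give about 25000 nM, within a range of 7000 nM to 80000 nM. This amounts to an estimated step of a 1.8-fold lower number from compound 1 to compound 3 (0.25 log units; within the scatter).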

Compound 3, concentration for 50% growth inhibition: 0.76 nM
Compound 3: middle estimate off by 33000-fold (4.52 log units), on the high side, and the stated range ends above it.
By their numbers in this assay, from the lowest: compound 3; then compound 2; then compound 1.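

In this assay, placing the group of 2 heavy atoms (1 carbon, 1 selenium) where methylsulfanyl stood, on a carbon with a double bond to nitrogen, gives a 59000-fold lower number from compound 1 to compound 3 (4.77 log units; beyond the scatter), a large step beyond the scatter. Among the compounds shown here, this is the first exchange isolated at this position, and it shows that the read-out can respond very strongly to a change of this one atom, with the heavy-atom count unchanged, no ring added and the rest of the core of compound 1 untouched. No measurement at hand bears on the origin of a step of this size.

Compound 2 has no sulfur counterpart among the compounds shown, so it remains open whether the same exchange gives a step of similar size on a different core, and one pair cannot establish a general pattern. As far as these compounds go, it is also open whether an ethyl chain or a methoxy group at this position would stay close to compound 3 at 0.76 nM or fall back toward compound 1 at 44700 nM.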